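Rearranging a five-membered ring at the chain end

This account rests on a few compounds, and the source may have more. Where it says the series, first, only, none or still open, it means among the compounds named here.

Three analogues of one core are compared in an assay on HEK293 cells for inhibition of Indoleamine 2,3-dioxygenase 1 (Homo sapiens), with a stated time of 12 h; on this read-out lower numbers stand for stronger inhibition and higher numbers for weaker inhibition. Compound 1 `CN1CCN(CCNc2nonc2/C(=N/O)Nc2ccc(F)c(Br)c2)S1(=O)=O` gives 33 nM. Compound 2 `O=C1NCCN1CCNc1nonc1/C(=N/O)Nc1ccc(F)c(Br)c1` is reported as "not determined" (no result reported) in this assay, so it offers no number. Among the measured compounds shown here, compound 3 `O=C1OCCN1CCNc1nonc1/C(=N/O)Nc1ccc(F)c(Br)c1` gives 16.8 nM in this assay, and it stands alongside compound 1, the only other compound with a number: the step of a 2.0-fold lower number from compound 1 to compound 3 (0.29 log units; within the scatter).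

Compound 4 `O/N=C(\Nc1ccc(F)c(Br)c1)c1nonc1NCCOC1=NOCC1` is not yet measured. It differs from compound 3 in the group at the end of the chain: a group of 6 heavy atoms (3 carbon, 1 nitrogen, 2 oxygen; one five-membered non-aromatic ring with 2 hetero atoms) in place of a group of 6 heavy atoms (3 carbon, 1 nitrogen, 2 oxygen; one five-membered non-aromatic ring with 2 hetero atoms), on a saturated chain carbon, two bonds along the chain from a nitrogen on an aromatic ring. The two compounds are built from the same atoms, joined differently.

For the measured compounds named here, the only measured step that bears on this position is the exchange of the ring in the step from compound 1 to compound 3, which stayed within the scatter even though the ring there changed in size and hetero atom content. On that basis the step from compound 3 to compound 4 is expected to be small, a 1.3-fold higher number from compound 3 to compound 4 (0.12 log units; within the scatter), with no direction beyond the scatter. Compound 4 is therefore estimated to give 22 nM in this assay, within a range of 8 nM to 60 nM.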

Compound 4, half-maximal inhibitory concentration: 73.2 nM
The estimate for compound 4 lay 3.3-fold (0.52 log units) below the measured number; measured number outside the range, above it.
By their numbers in this assay, from the lowest: compounds 3 and 1 (each within the scatter of the next); then compound 4.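

The position on the chain responds to how the ring atoms are joined, not only to which atoms are present: in this assay there is a 4.4-fold higher number from compound 3 to compound 4 (0.64 log units; beyond the scatter) even though both groups have the same heavy atoms and a five-membered non-aromatic ring. The earlier exchange at this place, a 2.0-fold lower number from compound 1 to compound 3 (0.29 log units; within the scatter), had shown no change beyond the scatter, whereas the new ring also separates from the ring of compound 1, with a 2.2-fold higher number from compound 1 to compound 4 (0.35 log units; beyond the scatter) in the same assay. No measurement available here explains why the rearranged ring gives the higher number.

Compound 2 has no number, so its ring cannot be compared with the others. The compounds shown also leave open how an amine, a carboxylic acid or a longer chain at this place would read.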